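The source may hold more compounds than are shown below. What is called first, only, known or untested is meant among the compounds shown, and "the series" means these compounds.

Working notes on the series. Compound 1 `FC(F)(F)c1cc(NC[C@H]2CCCCN2)c2cn[nH]c2c1` gives 24000 nM in an assay for inhibition of Indoleamine 2,3-dioxygenase 1 (Homo sapiens), with stated times of 10 min and 60 min; a lower number here means a stronger inhibitor, a higher number a weaker inhibitor. Among the three numbers in hand it stands second highest: compound 3 `O=[N+](O)c1c(Cl)cccc1CNc1cc(C(F)(F)F)cc2[nH]ncc12`, with 60000 nM, is nearest at a higher number, beyond the scatter, while compound 2 `O=[N+]([O-])c1ccc(O)cc1CNc1cc(Br)cc2[nH]ncc12`, with 910 nM, is furthest at a much lower number, also beyond the scatter. Compound 4 `FC(F)(F)c1cc(NCc2cccc(Br)c2)c2cn[nH]c2c1` has not yet been measured in this assay. It differs from compound 1 in one place: 3-bromophenyl in place of piperidin-2-yl on a saturated chain carbon bound to a nitrogen on an aromatic ring. Among the compounds with values here, no measured pair in the set shares this change, so no measured step fixes its size. Compound 2 with 910 nM and compound 3 with 60000 nM show that variation in this part of the series spans both low and high numbers on the same core type. The expected step from compound 1 to compound 4 is a 2.4-fold lower number from compound 1 to compound 4 (0.38 log units; beyond the scatter), a modest move toward a lower number, only somewhat beyond the scatter. Compound 4 is estimated at 10000 nM, with a range from 2000 nM to 50000 nM.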

Compound 4, half-maximal inhibitory concentration: > 100000 nM
Compound 4: a limit, no number (the forecaster's own chance of this, stated with the estimate: 10%); at least 10-fold (1.00 log units) between middle value and limit.
By their numbers in this assay, from the lowest: compound 2; then compound 1; then compound 3. At a limit, above all of these: compound 4.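

Within the data shown here, on the saturated chain carbon bound to a nitrogen on an aromatic ring, 3-bromophenyl in place of piperidin-2-yl gives an at least 4.1-fold higher number from compound 1 to compound 4 (0.61 log units; beyond the scatter), the first step that shows a direction for a change at this place. On the core of compound 1, an aromatic ring of carbon only at this place therefore does not keep a measurable number in this assay. The step has a floor and no upper end, because compound 4 gives a limit and not a number: the limit of > 100000 nM in this assay, at which 1 of the 4 values shown sits.

The change removes the non-aromatic ring with its nitrogen and brings in bromine together, so the compounds shown do not separate these two parts of the change. A plain phenyl or an open-chain amine at this place would bear on that question.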